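Working notes: the step from compound 1 to compound 3

The source may report more compounds than this note shows. Statements on the series, on what has been measured and on what is new or still open speak of the compounds shown alone.

In an ADME assay on microsomes from liver (Homo sapiens) for metabolic stability (a higher number here means faster removal of the compound, a lower number slower removal), compound 1 `CCCC(Oc1ccc(-n2cc(OC)cn2)cc1)c1ccc(C(=O)NCCC(=O)O)cc1` gives < 8 mL/min/kg as a limit of the assay and not a number. Compound 2 `CCC(Oc1ccc(-n2cc(C(F)(F)F)cn2)cc1)c1ccc(C(=O)NCCC(=O)O)cc1` gives < 8 mL/min/kg as a limit too. Among the measured compounds shown here, compound 3 `CCCC(Oc1ccc(-n2cc3c(n2)CCCC3)cc1)c1ccc(C(=O)NCCC(=O)O)cc1` carries a group of 9 heavy atoms (7 carbon, 2 nitrogen; one five-membered aromatic ring with 2 hetero atoms, one six-membered non-aromatic ring of carbon only) in place of a group of 7 heavy atoms (4 carbon, 2 nitrogen, 1 oxygen; one five-membered aromatic ring with 2 hetero atoms), on an aromatic carbon as its one change from compound 1, and the 4-methoxy-1H-pyrazol-1-yl group is lost. For the measured compounds named here, no measured step bears on this change. A small rise in this assay is expected, with an at least 1.2-fold higher number from compound 1 to compound 3 (0.09 log units; that floor lies within the scatter) as the estimated step and nothing clearly beyond the scatter. For compound 3 the estimate is 10 mL/min/kg with an expected range from 6 mL/min/kg to 20 mL/min/kg as its span.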

Compound 3, clearance: 48 mL/min/kg
Estimate against measurement, compound 3: 4.8-fold (0.68 log units) below, outside the stated range (above it).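

Among the compounds shown here, the change on the aromatic carbon, para to a large group, is the first to move this assay clear of the floor, with an at least 6.0-fold higher number from compound 1 to compound 3 (0.77 log units; beyond the scatter). So this position does not tolerate every group: the one with a six-membered non-aromatic ring of carbon only is not equivalent to 4-methoxy-1H-pyrazol-1-yl. The true size of the step cannot be read, as compound 1 stands at a limit of the assay: the limit of < 8 mL/min/kg in this assay, at which 2 of the 3 values shown sit.

As far as these compounds go, whether the added carbon ring alone drives the rise remains open. A 4-methyl-1H-pyrazol-1-yl group or an amine on the five-membered ring could separate that ring from the loss of the methoxy in this assay.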